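Sulfonamide nitrogen substituents on the shared core

The source may report more compounds than this note shows. Statements on the series, on what has been measured and on what is new or still open speak of the compounds shown alone.

Measured so far:
compound 1 `Cn1ccc2ccc(-c3cc(Nc4ccccc4S(N)(=O)=O)cc4nccnc34)cc21` — 37600 nM
compound 2 `CN(C)S(=O)(=O)c1ccccc1Nc1cc(-c2ccc3ccn(C)c3c2)c2nccnc2c1` — 7670 nM
compound 3 `Cn1ccc2ccc(-c3cc(Nc4ccccc4S(=O)(=O)Nc4cncnc4)cc4nccnc34)cc21` — > 100000 nM

In an assay on lysate for inhibition of 6-phosphofructo-2-kinase/fructose-2,6-bisphosphatase 3 (Homo sapiens), with stated times of 0.5 min and 45 min (a lower number here means a stronger inhibitor, a higher number a weaker inhibitor), compound 1 gives 37600 nM. Compound 2 gives 7670 nM, and between them there is a 4.9-fold lower number from compound 1 to compound 2 (0.69 log units; beyond the scatter). Compound 3 is reported in this assay only as a limit, > 100000 nM, and not as a number. Its place is therefore the top of the range shown: the limit of > 100000 nM in this assay, at which 1 of the 3 values shown sits. The steps of an at least 2.6-fold higher number from compound 1 to compound 3 (0.42 log units; beyond the scatter) and an at least 13-fold higher number from compound 2 to compound 3 (1.11 log units; beyond the scatter) show that placing pyrimidin-5-yl on the sulfonamide nitrogen weakened inhibition relative to both the unsubstituted and the dimethylated sulfonyl group.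

Compound 4 `CN1CCCC(NS(=O)(=O)c2ccccc2Nc2cc(-c3ccc4ccn(C)c4c3)c3nccnc3c2)C1` differs from compound 3 by 1-methylpiperidin-3-yl in place of pyrimidin-5-yl on a sulfonamide nitrogen. For the measured compounds named here, the measured steps bear on this change only indirectly: they record what the pyrimidin-5-yl substituent cost, but no measured compound carries a saturated substituent on this nitrogen, so the direction of the new step is open. The expectation is that compound 4 returns into the measurable range, with a step of an at least 2.5-fold lower number from compound 3 to compound 4 (0.39 log units; beyond the scatter) expected and a wide band of uncertainty around it. Compound 4 is estimated at 40000 nM, with a range from 8000 nM to 200000 nM.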

Compound 4, half-maximal inhibitory concentration: 9780 nM
Compound 4: middle estimate off by 4.1-fold (0.61 log units), on the high side; low and high end bracket the measured number.
By their numbers in this assay, from the lowest: compounds 2 and 4 (each within the scatter of the next); then compound 1. At a limit, above all of these: compound 3.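

Compound 3 is held only as a limit of the assay, so its step to compound 4 is a bound and not a measured size: the limit of > 100000 nM in this assay, at which 1 of the 4 values shown sits. A six-membered ring on the sulfonamide nitrogen therefore does not in itself cost inhibition in this assay: 1-methylpiperidin-3-yl in place of pyrimidin-5-yl gives an at least 10-fold lower number from compound 3 to compound 4 (1.00 log units; beyond the scatter). Against the unsubstituted sulfonamide the same substituent gives a 3.8-fold lower number from compound 1 to compound 4 (0.58 log units; beyond the scatter), while against the dimethylated sulfonyl group it gives a 1.3-fold higher number from compound 2 to compound 4 (0.11 log units; within the scatter), so compound 2 and compound 4 cannot be told apart here, and among the substituted compounds only compound 3 goes against a gain over compound 1.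

The change from compound 3 to compound 4 replaces the aromatic ring, the number of ring nitrogens and the methyl group in one step, and these compounds do not separate their contributions. A cyclohexyl group, a phenyl ring or a piperidin-3-yl group without the methyl on the sulfonamide nitrogen would bear on that question, and the 1-methylpiperidin-4-yl group would test whether the attachment point of the ring matters.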